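The source may hold more compounds than are shown below. What is called first, only, known or untested is meant among the compounds shown, and "the series" means these compounds.

In a functional assay on A549 cells (Homo sapiens) for cytotoxicity, read by MTT assay, with a stated time of 72 h (a lower number here means a stronger inhibitor, a higher number a weaker inhibitor), compound 1 `O=C1c2c[n+]([O-])c3ccccc3c2C(=O)c2c1c1ccccc1n2Cc1cn(C[C@H](O)CO)nn1` gives 1030 nM, compound 2 `CCCCN1CCN(CCCCn2c3c(c4ccccc42)C(=O)c2c[n+]([O-])c4ccccc4c2C3=O)CC1` gives 550 nM, and compound 3 `O=C1c2c[n+]([O-])c3ccccc3c2C(=O)c2c1c1ccccc1n2CCCCN1CCCCC1` gives 150 nM, the lowest of the three numbers. Compound 4 `O=C1c2c[n+]([O-])c3ccccc3c2C(=O)c2c1c1ccccc1n2CCN1CCCCC1` keeps the shared core of compound 3 but shortens the side chain from 4-(piperidin-1-yl)butyl to 2-(piperidin-1-yl)ethyl: piperidin-1-yl in place of 2-(piperidin-1-yl)ethyl on a saturated chain carbon, two bonds along the chain from an aromatic nitrogen. Among the measured compounds shown here, no measured pair changes chain length alone. The nearest guides are side-chain swaps, a 3.7-fold lower number from compound 2 to compound 3 (0.56 log units; beyond the scatter) and a 6.9-fold lower number from compound 1 to compound 3 (0.84 log units; beyond the scatter), both modest. A modest step at most therefore seems likely, and a higher number is the likelier direction, since compound 3 at 150 nM already sits lowest. The estimated step is a 1.7-fold higher number from compound 3 to compound 4 (0.22 log units; within the scatter). In this assay, compound 4 is expected at about 250 nM, within an estimated range of 80 nM to 750 nM.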

Compound 4, half-maximal inhibitory concentration: 1080 nM
Beside the measured number, compound 4's estimate is 4.3-fold (0.64 log units) below it; the measured number lies above the stated range.
By their numbers in this assay, from the lowest: compound 3; then compounds 2, 1 and 4 (each within the scatter of the next).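

In this assay, with the piperidine ring kept, chain length alone gives a 7.2-fold higher number from compound 3 to compound 4 (0.86 log units; beyond the scatter), so the distance from the aromatic nitrogen to that ring matters here, as the earlier side-chain swaps could not show. The shorter chain also loses the lead of compound 3, with a 2.0-fold higher number from compound 2 to compound 4 (0.29 log units; within the scatter) and a 1.0-fold higher number from compound 1 to compound 4 (0.02 log units; within the scatter), both within the scatter. No measurement shown here explains the shift.

Still open, as far as these compounds go, is whether a longer chain, such as 5-(piperidin-1-yl)pentyl, continues the trend. Also open, from the compounds shown here alone, is whether morpholin-4-yl on the butyl chain would match compound 3.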